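Adding Methoxy to the Core of Compound 1

The compounds below may be only part of what the source reports. "The series", "measured", "known", "first", "only" and "open" are said of these compounds alone.

In a functional assay on ASPC1 cells (Homo sapiens) for cytotoxicity (a lower number here means a stronger inhibitor, a higher number a weaker inhibitor), compound 1 `O=C(CCCCCCC(=O)Nc1nc2ccccc2s1)NO` gives 5.69 ug/mL. This is the lower of the two numbers available, and compound 2 `Cc1ccc2nc(NC(=O)CCCCC(=O)NO)sc2c1` gives 13.3 ug/mL, a gap beyond the scatter. Compound 3 `O=C(CCCCC(=O)Nc1nc2ccc([N+](=O)[O-])cc2s1)NO` reaches only a limit in this assay, > 30 ug/mL.

Compound 4 `COc1ccc2nc(NC(=O)CCCCCCC(=O)NO)sc2c1` keeps the chain of compound 1 and differs from it by methoxy in place of hydrogen on an aromatic carbon. Among the measured compounds shown here, one measured step bears on this change: an at least 2.2-fold higher number from compound 2 to compound 3 (0.35 log units; beyond the scatter), with nitro in place of methyl on an aromatic carbon. That step shows that a swap on an aromatic carbon can move the number, but it ends in a limit and involves neither hydrogen nor methoxy. It therefore gives only weak guidance on direction, and a small rise is the most that can be expected. The expected step is a 1.2-fold higher number from compound 1 to compound 4 (0.09 log units; within the scatter), which stays within the scatter. For compound 4 the estimated value is 7 ug/mL, with an expected range from 2.5 ug/mL to 20 ug/mL.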

Compound 4, half-maximal inhibitory concentration: 0.79 ug/mL
Estimate against measurement, compound 4: 8.9-fold (0.95 log units) above; the whole stated range lies above it.
By their numbers in this assay, from the lowest: compound 4; then compound 1; then compound 2. At a limit, above all of these: compound 3.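

In this assay, methoxy in place of hydrogen on an aromatic carbon, meta to a fused ring and para to a fused ring, gives a 7.2-fold lower number from compound 1 to compound 4 (0.86 log units; beyond the scatter), so this position on the shared core can carry a group with a lower number as the result. Unlike the earlier step, which swapped nitro for methyl and ended in a limit, this step has a full number at both ends, and hydrogen is the group that leaves, so its direction and size can both be read. Nothing shown here accounts for the size of this step.

The compounds shown leave open whether a hydroxyl, an ethoxy or an amine at this position would give a similar number. They also leave open whether methoxy would lower the number on the shorter chain of compound 2.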